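Aniline methyl removal in a sulfonamide-bearing quinazoline-like series

A few compounds are considered here, and "the series" means these few. Any claim that something is new, unique, unknown or untested is made for them only; others in the source may bear on it.

Within the data shown here, compound 2 `COc1cc2ncnc(Nc3ccc(C)cc3)c2cc1OCCCCC(=O)Nc1ccc(S(N)(=O)=O)cc1` carries the highest of the two numbers measured so far in a functional assay on NCI-H1975 cells (Homo sapiens) for antiproliferative activity, read by MTT assay, with a stated time of 72 h; a higher number here means a weaker inhibitor, a lower number a stronger inhibitor: compound 2 gives 19300 nM. Its nearest neighbour is compound 1 `COc1cc2ncnc(Nc3cccc(Br)c3)c2cc1OCCCCC(=O)Nc1ccc(S(N)(=O)=O)cc1`, which in this assay gives 11400 nM; the step of a 1.7-fold higher number from compound 1 to compound 2 (0.23 log units; within the scatter) lies within the scatter, so the two stand level. Compound 3 `COc1cc2ncnc(Nc3ccccc3)c2cc1OCCCCC(=O)Nc1ccc(S(N)(=O)=O)cc1` is not yet measured. It differs from compound 2 by hydrogen in place of methyl on an aromatic carbon, the (4-methylphenyl)amino group becoming anilino. Among the measured compounds shown here, the only measured step touching this part of the molecule is a 1.7-fold higher number from compound 1 to compound 2 (0.23 log units; within the scatter), an exchange of one substituent for another with no effect beyond the scatter; no measured step removes a substituent outright. On that basis no shift beyond the scatter is expected for compound 3 in this assay, the step of a 1.1-fold lower number from compound 2 to compound 3 (0.06 log units; within the scatter) being the estimate. Compound 3 is therefore estimated at 17000 nM, with a range from 7000 nM to 45000 nM.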

Compound 3, half-maximal inhibitory concentration: 14100 nM
The estimate for compound 3 lay 1.2-fold (0.08 log units) above the measured number; the range from low to high includes it.
By their numbers in this assay, from the lowest: compounds 1, 3 and 2 (each within the scatter of the next).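

In this assay taking a substituent off the aniline ring outright can now be read: hydrogen in place of methyl, para to a large group, gives a 1.4-fold lower number from compound 2 to compound 3 (0.14 log units; within the scatter), and hydrogen in place of bromo gives a 1.2-fold higher number from compound 1 to compound 3 (0.09 log units; within the scatter). The unsubstituted anilino compound 3 therefore stands level with compound 1 and compound 2, so neither methyl nor bromo separates from hydrogen on this ring in this series. No measurement on hand gives a reason for these numbers.

On these data alone, whether any group on this ring can move the number beyond the scatter stays open, for instance an amine or a trifluoromethyl group in place of the methyl. Also open, as far as these compounds go, is the response to changes away from this ring, such as a shorter chain or a carboxylic acid in place of the sulfonamide.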